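Phenyl in Place of Phenoxymethyl: Expectation for Compound 4

The source may hold more compounds than are shown below. What is called first, only, known or untested is meant among the compounds shown, and "the series" means these compounds.

Compound 1, `CCN(C(=O)c1ccccc1OCc1ccccc1)[C@@H]1CCC[C@H](NC(C)=O)C1`: in an assay on HEK293 cells for inhibition of transient receptor potential cation channel subfamily M member 8 (Homo sapiens), read by FLIPR and calcium flux (a higher number here means a weaker inhibitor, a lower number a stronger inhibitor), compound 1 gives > 5000 nM, which is a limit of the assay and not a number.
Compound 2, `CCN(C(=O)c1ccccc1OCc1ccccc1)C1CCNC1`: in this assay compound 2 gives > 5000 nM, again a limit of the assay.
Compound 3, `CCN(C(=O)c1ccccc1COc1ccccc1)[C@@H]1CCC[C@H](N)C1`: in this assay compound 3 gives 280 nM.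

Compound 3 is thus the only one of the three with a measured number; the other two sit at the limit of > 5000 nM in this assay, at which 2 of the 3 values shown sit. Among the measured compounds shown here, no two of the measured compounds differ in a single place, so no measured step is available to guide the next change.

Compound 4, `CCN(C(=O)c1ccccc1-c1ccccc1)[C@@H]1CCC[C@H](N)C1`, differs from compound 3 by phenyl in place of phenoxymethyl on an aromatic carbon. For the measured compounds named here, with no measured step of this kind to draw on, the expectation rests on where compound 3 stands alone, and a step of a 2.9-fold higher number from compound 3 to compound 4 (0.46 log units; beyond the scatter) toward a weaker inhibitor is expected, with wide uncertainty that reaches into the scatter on one side and toward the limit on the other. Compound 4 is accordingly expected to give about 800 nM, with a range from 200 nM to 4000 nM.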

Compound 4, antagonist equilibrium constant: > 2000 nM
Compound 4: a limit, no number (the forecaster's own chance of this, stated with the estimate: 30%); at least 2.5-fold (0.39 log units) between middle value and limit.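

Among the compounds shown here, the replacement of phenoxymethyl by phenyl on an aromatic carbon, ortho to a large group, gives an at least 7.1-fold higher number from compound 3 to compound 4 (0.85 log units; beyond the scatter) in this assay, and it is the first single-place step in the set, which the earlier compounds could not provide. The value of compound 4, > 2000 nM, is a limit of the assay and not a number. The step shows that, with the rest of compound 3 unchanged, the measured activity does not survive this change at this position, though its size has only a lower bound: the limit of > 2000 nM in this assay, at which 1 of the 4 values shown sits.

The compounds shown leave open whether the ring oxygen link, the methylene link or both account for the step. A benzyl, phenoxy or phenethyl group on the same aromatic carbon would bear on that question.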